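Cyclopropyl ring added beside the acid of compound 2

The source may report more compounds than this note shows. Statements on the series, on what has been measured and on what is new or still open speak of the compounds shown alone.

Measured compounds:
- compound 1, `CC(C)CC1(O)CCN(C(=O)Nc2cc(Oc3ccc(C(=O)O)cc3)cc(Oc3ccc(F)cc3F)c2)CC1`: 20 nM
- compound 2, `CC(C)CC1(O)CCN(C(=O)Nc2cc(Oc3ccc(F)cc3)cc(Oc3ccc(CC(=O)O)cc3)c2)CC1`: 21 nM

Both values come from a functional assay on CHO cells for antagonist activity at sphingosine 1-phosphate receptor 2 (Homo sapiens), read by fluorescence; on this read-out lower numbers stand for stronger inhibition and higher numbers for weaker inhibition. Compound 1 gives 20 nM, and compound 2 gives 21 nM. These two numbers lie within the usual scatter of each other, so neither compound can be called stronger than the other; compound 2 simply sits at one end of this small pair.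

Compound 3, `CC(C)CC1(O)CCN(C(=O)Nc2cc(Oc3ccc(F)cc3)cc(Oc3ccc(C4(C(=O)O)CC4)cc3)c2)CC1`, has not yet been tested. It differs from compound 2 in one place: 1-carboxycyclopropyl in place of carboxymethyl on an aromatic carbon. The acid group stays, but the single carbon that carried it is now part of a small three-membered ring.

Within the data shown here, no measured pair shows what this kind of change does in this assay. With only the two numbers above as a guide, the step from compound 2 to compound 3 is expected to be small, roughly a 1.4-fold higher number from compound 2 to compound 3 (0.15 log units; within the scatter), and not clearly beyond the scatter in either direction. Compound 3 is therefore estimated at 30 nM, with a plausible range from 10 nM to 90 nM.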

Compound 3, half-maximal inhibitory concentration: 6.4 nM
Compound 3: the middle estimate sits 4.7-fold (0.67 log units) above what was measured, outside the stated range (below it).
By their numbers in this assay, from the lowest: compound 3; then compounds 1 and 2 (each within the scatter of the next).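

In this assay, putting 1-carboxycyclopropyl in place of carboxymethyl gives a 3.3-fold lower number from compound 2 to compound 3 (0.52 log units; beyond the scatter), so the number responds to changes at this site on the ring. The acid group stays in both compounds; what changes is the carbon that carries it, which is now part of a three-membered ring, and this single edit moves the number beyond the scatter. No measurement is available that would explain the drop.

Going by these compounds, whether this result belongs to the three-membered ring itself stays open: two methyl groups on that same carbon, or a four-membered carbon ring there, would help to settle it. Also open, on these data alone, is whether a tetrazole could take the place of the carboxylic acid on this carbon and hold the number.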